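Replacing a bromophenyl with a hydroxyethyl on a shared core

The compounds below may be only part of what the source reports. "The series", "measured", "known", "first", "only" and "open" are said of these compounds alone.

Compound 1, with the structure `COc1nc2ccc(Br)cc2cc1C(c1ccccc1)n1cc(-c2ccc(Br)cc2)nn1`, was tested in an ADME assay on PANC-1 cells (Homo sapiens) for cytotoxicity, read by sulforhodamine B assay, with a stated time of 48 h, tested at 10 uM; a higher number here means more inhibition at the concentration tested (going by the name of the read-out), a lower number less inhibition. In this assay, for the measured compounds named here, compound 1 gives 10.4%, which is the lowest of the two numbers measured so far. Its nearest neighbour is compound 2, with the structure `CCOC(=O)c1cn(C(c2ccccc2)c2cc3cc(Br)ccc3nc2OC)nn1`, which in this assay gives 15.4%; the step between them, a number 5 percentage points higher from compound 1 to compound 2 (within the scatter), lies within the scatter, so the two compounds cannot be told apart on these numbers.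

Compound 3, with the structure `COc1nc2ccc(Br)cc2cc1C(c1ccccc1)n1cc(CCO)nn1`, has not yet been measured in this assay. It differs from compound 1 in one place: 2-hydroxyethyl in place of 4-bromophenyl on an aromatic carbon.

Going by the values given here, only one measured step bears on this change. The step from compound 1 to compound 2 swaps the same 4-bromophenyl group on the same aromatic carbon for a different group, and that swap moved the number by an amount within the scatter. On this basis no step beyond the scatter is expected for the swap to 2-hydroxyethyl, and the estimated step is a number 1.6 percentage points higher from compound 1 to compound 3 (within the scatter). Compound 3 is therefore expected to give about 12% in this assay, with a likely range from 0% to 27%.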

Compound 3, a percentage reported as inhibition, at one concentration (the size of the read-out at that concentration, not a potency): 19.8%
Compound 3: the middle estimate sits 7.8 percentage points below what was measured; the range from low to high includes it.
By their numbers in this assay, from the lowest: compounds 1, 2 and 3 (each within the scatter of the next).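

In this assay, the 4-bromophenyl group on this aromatic carbon was exchanged for 2-hydroxyethyl, a group with no ring, fewer heavy atoms and a hydrogen-bond donor, and this gave a number 9.4 percentage points higher from compound 1 to compound 3 (within the scatter) on the shared core. Exchanging ethoxycarbonyl for 2-hydroxyethyl at the same place gave a number 4.4 percentage points higher from compound 2 to compound 3 (within the scatter), so the three groups now shown at this position, one with an aromatic ring and two without, cannot be told apart in this measurement. No measurement at hand speaks to what lies behind these numbers.

As far as these compounds go, it remains open whether any group at this position can move the number beyond the scatter, and an amine, a carboxylic acid or a chain longer than 2-hydroxyethyl on the same core would test this further. Each number also comes from a single concentration, so differences in potency among the three compounds could remain hidden.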